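Hydroxylated ring and aryl exchange in dienone series

The compounds below may be only part of what the source reports. "The series", "measured", "known", "first", "only" and "open" are said of these compounds alone.

Compound 1 `CC1=C(/C=C/C(=O)/C=C/c2ccc(F)cc2)C(C)(C)CCC1` and compound 2 `CC1=C(/C=C/C(=O)/C=C/c2cccc(C)c2)C(C)(C)CCC1` share an unsubstituted saturated ring core; compound 3 `CC1=C(/C=C/C(=O)/C=C/c2ccc(F)cc2)C(C)(C)CCC1O` and compound 4 `CC1=C(/C=C/C(=O)/C=C/c2cccc(C)c2)C(C)(C)CCC1O` carry the same chain but a hydroxy on the ring. In a functional assay on PC-3 cells (Homo sapiens) for cytotoxicity, read by MTT assay, with a stated time of 72 h (a lower number here means a stronger inhibitor, a higher number a weaker inhibitor), compound 1 gives 25800 nM, compound 2 gives 35000 nM and compound 3 gives 6200 nM; compound 4 is not yet measured there.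

The two cores differ by hydroxy in place of hydrogen on a saturated ring carbon, and the step of a 4.2-fold lower number from compound 1 to compound 3 (0.62 log units; beyond the scatter) is the one clear movement in the set, leaving compound 3 with the lowest number of the three measured compounds.

The aryl exchange 3-methylphenyl in place of 4-fluorophenyl on a double-bonded chain carbon bound to a double-bonded chain carbon produced the step of a 1.4-fold higher number from compound 1 to compound 2 (0.13 log units; within the scatter), a movement that does not stand out from repeat variation. The same change, (3-methylphenyl in place of 4-fluorophenyl on a double-bonded chain carbon bound to a double-bonded chain carbon), now connects compound 3 to compound 4, at the same place on the chain in both pairs, so the unmeasured result rests on a single earlier instance of the exchange on a different core.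

For compound 4 in this assay the step is expected to resemble the earlier one, that is a 1.4-fold higher number from compound 3 to compound 4 (0.14 log units; within the scatter), because compound 1 to compound 2 showed a 1.4-fold higher number from compound 1 to compound 2 (0.13 log units; within the scatter). Among the measured compounds shown here, compound 4 is therefore estimated at 8500 nM in this assay, with a range of 4000 nM to 18000 nM; the width reflects that only one prior example of the exchange exists and that it sits on the core of compound 1 rather than that of compound 3.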

Compound 4, half-maximal inhibitory concentration: 6200 nM
For compound 4 the middle estimate is 1.4-fold (0.14 log units) above the measured one; the measured number falls inside the stated range.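

In this assay, among the compounds shown here, 3-methylphenyl in place of 4-fluorophenyl gives no change at the digits printed from compound 3 to compound 4 (within the scatter), and the exchange behaves alike on the two cores, leaving the number inside the scatter on each: the same change on two cores in this assay, a 1.4-fold higher number (0.13 log units; within the scatter) from compound 1 to compound 2 and no change at the digits printed (within the scatter) from compound 3 to compound 4, 1.4-fold (0.13 log units) apart, within the scatter of two such steps Hydroxy in place of hydrogen on a saturated ring carbon gives a 5.6-fold lower number from compound 2 to compound 4 (0.75 log units; beyond the scatter), so this change also carries over, with the gain seen with 4-fluorophenyl present again with 3-methylphenyl present: the same change on two cores in this assay, a 4.2-fold lower number (0.62 log units; beyond the scatter) from compound 1 to compound 3 and a 5.6-fold lower number (0.75 log units; beyond the scatter) from compound 2 to compound 4, 1.4-fold (0.13 log units) apart, within the scatter of two such steps Within these four compounds the two changes therefore read as independent of each other, so the effect of either could be carried to the other core, but this rests on only two pairs per change, in a single cytotoxicity read-out on one cell line, and it gives no explanation for either step and no assurance for other aryl groups or other cores.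

From the compounds shown here alone, it remains open whether a more different group at the same chain position, such as a phenyl bearing an amine or a carboxylic acid, would also leave the number unmoved in this assay. Going by these compounds, it is equally open whether a methoxy or a carbonyl at the ring carbon that carries the hydroxy would keep the lower number seen with the hydroxy.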